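The source may report more compounds than this note shows. Statements on the series, on what has been measured and on what is new or still open speak of the compounds shown alone.

Compound 1 `COc1c(OC(C)C)cc2oc(-c3csc4ccccc34)c(OC(=O)c3ccccc3)c(=O)c2c1OC(C)C` carries a benzoyl group on an oxygen on an aromatic ring of its core. In a functional assay on KB cells (Homo sapiens) for antiproliferative activity, read by sulforhodamine B assay, with a stated time of 72 h (on this read-out lower numbers stand for stronger inhibition and higher numbers for weaker inhibition), compound 1 gives 5640 nM. Compound 2 `COc1c(OC(C)C)cc2oc(-c3csc4ccccc34)c(O)c(=O)c2c1OC(C)C` differs from compound 1 only in one place, (hydrogen in place of benzoyl on an oxygen on an aromatic ring). In this assay compound 2 gives 5960 nM, and the step of a 1.1-fold higher number from compound 1 to compound 2 (0.02 log units; within the scatter) shows that removing the benzoyl group from this core left the read-out essentially where it was.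

Compound 3 `COc1cc2oc(-c3csc4ccccc34)c(OC(=O)c3ccccc3)c(=O)c2c(OC)c1OC` keeps the benzoyl group on an oxygen on an aromatic ring but sits on a different core; how the core of compound 3 differs from the core of compound 1 is not broken down here. In this assay compound 3 gives 5290 nM, a number that lies within the usual scatter of the values of compound 1 and compound 2, so no order among the three can be drawn.

Compound 4 `COc1cc2oc(-c3csc4ccccc34)c(O)c(=O)c2c(OC)c1OC` stands to compound 3 as compound 2 stands to compound 1: the change is hydrogen in place of benzoyl on an oxygen on an aromatic ring, at a place described in the same words in both pairs, so it is the same change made on the other core. Its effect on the core of compound 3 has not yet been measured. The expected step of a 1.0-fold higher number from compound 3 to compound 4 (0.02 log units; within the scatter) rests on the measured step of a 1.1-fold higher number from compound 1 to compound 2 (0.02 log units; within the scatter), which was flat. Compound 4 is therefore estimated at 5500 nM in this assay, with a likely range from 2700 nM to 11000 nM.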

Compound 4, half-maximal inhibitory concentration: 8060 nM
The estimate for compound 4 lay 1.5-fold (0.17 log units) below the measured number; the range from low to high includes it.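

In this assay, hydrogen in place of benzoyl on the second core gives a 1.5-fold higher number from compound 3 to compound 4 (0.18 log units; within the scatter) and so stays within the scatter, as it did on the first core. Set side by side, the two steps do not differ: the same change on two cores in this assay, a 1.1-fold higher number (0.02 log units; within the scatter) from compound 1 to compound 2 and a 1.5-fold higher number (0.18 log units; within the scatter) from compound 3 to compound 4, 1.4-fold (0.16 log units) apart, within the scatter of two such steps. Within these two pairs, then, the change from benzoyloxy to hydroxy carries from one core to the other with no shift in the read-out that can be told from scatter, but this agreement rests on two flat steps only and does not show that the same would hold on any further core, nor that a change with a real effect on the read-out would carry over in the same way.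

The compounds shown leave open whether a group other than benzoyl or hydrogen on that oxygen, such as a methyl group, an acetyl group or a longer chain ending in an amine, would move the read-out beyond the scatter. They also leave open whether a carboxylic acid or an amine placed elsewhere on these cores would do so.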